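Trifluoromethoxy in place of chloro: compound 2 to compound 3

The source may hold more compounds than are shown below. What is called first, only, known or untested is meant among the compounds shown, and "the series" means these compounds.

Of the compounds shown here, two sharing one core have been measured in an ADME assay on A549 cells (Homo sapiens) for cytotoxicity, read by CellTiter-Glo; a higher number here means that more compound is tolerated, a lower number that less compound is tolerated. Compound 1, `Cc1c(Cc2ccccc2)c(=O)oc2cc(OCC(O)CNc3nccs3)ccc12`, gives 93000 nM. Compound 2, `Cc1c(Cc2ccc(Cl)cc2)c(=O)oc2cc(OCC(O)CN3CCC(C(N)=O)CC3)ccc12`, gives 40000 nM, the lower of the two numbers, so less of compound 2 is tolerated than of compound 1, and the gap between them lies beyond the usual scatter. These two compounds differ in more than one place, so nothing can be separated out about either change on its own.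

Compound 3, `Cc1c(Cc2ccc(OC(F)(F)F)cc2)c(=O)oc2cc(OCC(O)CN3CCC(C(N)=O)CC3)ccc12`, keeps the rest of compound 2 and changes one point only: trifluoromethoxy in place of chloro on an aromatic carbon. Going by the values given here, no measured pair shows this same exchange, so there is nothing to go on beyond the number for compound 2. The exchange is expected to give only a small step, a 1.1-fold lower number from compound 2 to compound 3 (0.06 log units; within the scatter), with no clear direction and within the scatter. Compound 3 is therefore estimated at 35000 nM, within a range from 14000 nM to 90000 nM.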

Compound 3, half-maximal cytotoxic concentration: 68200 nM
The estimate for compound 3 lay 1.9-fold (0.29 log units) below the measured number, within the range that was stated.
By their numbers in this assay, from the lowest: compounds 2, 3 and 1 (each within the scatter of the next, the first and the last beyond it).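

Going by these compounds alone, compound 2 and compound 3 form the first pair here that differs in one place, and in this assay the exchange of 4-chlorobenzyl for 4-(trifluoromethoxy)benzyl gives a 1.7-fold higher number from compound 2 to compound 3 (0.23 log units; within the scatter) and stays within the scatter. At this aromatic carbon, para to a large group, 5 heavy atoms can therefore enter where 1 leaves with no change that these numbers can separate from repeat measurements. Nothing available accounts for this result.

From the compounds shown here alone, whether a different group at this position, such as methoxy, an amine or a carboxylic acid, would give a step beyond the scatter remains open. The gap between compound 1 and compound 2 also remains unassigned, as those two compounds differ in more than one place.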